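Naphthyloxyacetyl hydrazones: partition coefficient notes

The source may report more compounds than this note shows. Statements on the series, on what has been measured and on what is new or still open speak of the compounds shown alone.

Measured so far:
compound 1 `C/C(=N\NC(=O)COc1cccc2ccccc12)c1ccc(O)cc1O` 4.31
compound 2 `COc1ccc(/C=N/NC(=O)COc2cccc3ccccc23)cc1O` 3.48

In a physicochemical assay for lipophilicity, measured as octanol-water partition (on this read-out higher numbers stand for higher lipophilicity and lower numbers for lower lipophilicity), compound 1 gives 4.31, the higher of the two numbers; compound 2 gives 3.48, a gap beyond the scatter. Compound 3 `C/C(=N\NC(=O)COc1cccc2ccccc12)c1cccc([N+](=O)[O-])c1` is not yet measured. It differs from compound 1 in one place: 3-nitrophenyl in place of 2,4-dihydroxyphenyl on a carbon with a double bond to nitrogen. Both 2,4-dihydroxyphenyl hydrogen-bond donors leave and none enters, so a rise beyond the scatter is expected for compound 3, the step of a number 0.59 log units higher from compound 1 to compound 3 (beyond the scatter). Compound 3 is expected at 4.9, in a range from 4.3 to 5.5.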

Compound 3, partition coefficient: 3.37
Compound 3: the middle estimate sits 1.53 log units above what was measured; the measured number lies below the stated range.
By their numbers in this assay, from the lowest: compounds 3 and 2 (each within the scatter of the next); then compound 1.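

In this assay 3-nitrophenyl in place of 2,4-dihydroxyphenyl on a carbon with a double bond to nitrogen gives a number 0.94 log units lower from compound 1 to compound 3 (beyond the scatter) on the shared core. At this position, then, losing the hydrogen-bond donors of 2,4-dihydroxyphenyl goes with a fall, not a rise, in this one pair. Nothing available here accounts for the direction of the step.

This single pair cannot separate the departure of the two hydroxyl groups from the arrival of the nitro group. An unsubstituted phenyl or a 3-aminophenyl at the same place would help to tell these apart.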